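The source may hold more compounds than are shown below. What is called first, only, known or untested is meant among the compounds shown, and "the series" means these compounds.

Working notes on the series. In a functional assay on HeLa cells (Homo sapiens) for inhibition, read by CCK-8 assay, with a stated time of 72 h (on this read-out lower numbers stand for stronger inhibition and higher numbers for weaker inhibition), compound 1 `Nc1ccccc1NC(=O)c1ccc(CNC(=O)c2n[nH]cc2NC(=O)c2c(F)cccc2Cl)cc1` gives 3270 nM, within the scatter of both compound 2 `O=C(NO)c1ccc(CNC(=O)c2n[nH]cc2NC(=O)c2c(Cl)cccc2Cl)cc1` at 4840 nM and compound 3 `Nc1ccccc1NC(=O)c1ccc(CNC(=O)c2n[nH]cc2NC(=O)c2c(Cl)cccc2Cl)cc1` at 1830 nM. The next structure is compound 4 `Nc1ccccc1NC(=O)c1ccc(CNC(=O)c2n[nH]cc2NC(=O)c2ccccc2F)cc1`, with hydrogen in place of chloro on an aromatic carbon: 2-chloro-6-fluorophenyl becomes 2-fluorophenyl. Among the compounds with values here, the only measured step touching these halogens is a 1.8-fold lower number from compound 1 to compound 3 (0.25 log units; within the scatter). The other, a 2.6-fold lower number from compound 2 to compound 3 (0.42 log units; beyond the scatter), concerns the group on the amide-type nitrogen and does not bear on this change. Within the data shown here, no measured compound lacks the second halogen, so the evidence is thin. A small rise is expected in this assay, a 1.4-fold higher number from compound 1 to compound 4 (0.14 log units; within the scatter). Compound 4 is estimated at 4500 nM, with an expected range of 2000 nM to 10000 nM.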

Compound 4, half-maximal inhibitory concentration: 3440 nM
Beside the measured number, compound 4's estimate is 1.3-fold (0.12 log units) above it, within the range that was stated.
By their numbers in this assay, from the lowest: compounds 3, 1, 4 and 2 (each within the scatter of the next, the first and the last beyond it).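

Hydrogen in place of chloro on 2-chloro-6-fluorophenyl leaves the number in this assay within the scatter (a 1.1-fold higher number from compound 1 to compound 4 (0.02 log units; within the scatter)), so at this position the second halogen is not needed to hold the value when fluoro remains. The wider change from 2,6-dichlorophenyl to 2-fluorophenyl also stays within the scatter (a 1.9-fold higher number from compound 3 to compound 4 (0.27 log units; within the scatter)). Nothing on hand gives a reason for this flat result. Still open, on these data alone, is whether a methoxy group or an amine at this place would move the number, and whether a phenyl without fluoro would hold it.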